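Changing the Amine Substituent of Compound 2

This account rests on a few compounds, and the source may have more. Where it says the series, first, only, none or still open, it means among the compounds named here.

Measured so far:
compound 1 `COC[C@H](NC1CCN(CCCc2c[nH]c3ccc(Cn4cncn4)cc23)CC1)c1ccc(F)cc1` — 8.9 nM
compound 2 `COC[C@H](NC1CCN(CCCc2c[nH]c3ccc(-n4cnnc4)cc23)CC1)c1ccccc1` — 0.9 nM
compound 3 `c1ccc(C2CCCCN2C2CCN(CCCc3c[nH]c4ccc(-n5cnnc5)cc34)CC2)cc1` — 4.7 nM

In an assay on CHO cells for agonist activity at 5-hydroxytryptamine receptor 1D (Homo sapiens), read by GTPgammaS binding (on this read-out higher numbers stand for an effect only at larger amounts of compound and lower numbers for an effect already at smaller amounts), compound 2 gives the lowest number of the three; compound 3 sits higher by a gap beyond the usual scatter, and compound 1 higher still. Compound 4 `O[C@@H]1Cc2ccccc2[C@H]1NC1CCN(CCCc2c[nH]c3ccc(-n4cnnc4)cc23)CC1` has not yet been measured. It differs from compound 2 in one place: 2-hydroxy-2,3-dihydro-1H-inden-1-yl in place of 2-methoxy-1-phenylethyl on an amine nitrogen. Going by the values given here, no step between measured compounds that differ in one place is known, so the effect of this change can only be guessed from compound 3, which carries another group on the same nitrogen and still stays fairly close to compound 2. Compound 4 is therefore expected to give a somewhat higher number than compound 2, a step of a 2.8-fold higher number from compound 2 to compound 4 (0.44 log units; beyond the scatter). Compound 4 is estimated at 2.5 nM, between 0.8 nM and 8 nM.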

Compound 4, half-maximal effective concentration: 13 nM
Beside the measured number, compound 4's estimate is 5.2-fold (0.72 log units) below it; measured number above the stated range.
By their numbers in this assay, from the lowest: compound 2; then compounds 3, 1 and 4 (each within the scatter of the next, the first and the last beyond it).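

In this assay, this amine nitrogen does not treat two groups of equal heavy-atom count alike: 2-hydroxy-2,3-dihydro-1H-inden-1-yl in place of 2-methoxy-1-phenylethyl gives a 14-fold higher number from compound 2 to compound 4 (1.16 log units; beyond the scatter) in a single change. That change adds a five-membered ring, a hydrogen-bond donor and a second defined stereocentre all at once, so this one step cannot assign the shift to any of them. Nothing available explains its size.

Still open, from the compounds shown here alone, is whether the closed ring or the free hydroxy group matters more. 2-Hydroxy-1-phenylethyl or 2-methoxy-2,3-dihydro-1H-inden-1-yl on the same nitrogen would separate the two.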